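Nitro for Chloro on the Aryl Ring: Expected Cytotoxicity

The source may report more compounds than this note shows. Statements on the series, on what has been measured and on what is new or still open speak of the compounds shown alone.

Compound 1 `CN1CCN(c2ccc(Nc3nccc(-c4cccc(Cl)c4)n3)cc2C(F)(F)F)CC1`: 5280 nM
Compound 2 `CN1CCN(c2ccc(Nc3nccc(-c4cccnc4)n3)cc2C(F)(F)F)CC1`: 1060 nM

In a toxicity assay on THP-1 cells (Homo sapiens) for cytotoxicity, read by luminescence and CellTiter-Glo, with a stated time of 72 h (on this read-out lower numbers stand for higher toxicity in this test and higher numbers for lower toxicity in this test), compound 1 gives 5280 nM, the highest of the two numbers, while compound 2 gives 1060 nM, and the step of a 5.0-fold lower number from compound 1 to compound 2 (0.70 log units; beyond the scatter) is modest but beyond the scatter. Compound 3 `CN1CCN(c2ccc(Nc3nccc(-c4cccc([N+](=O)[O-])c4)n3)cc2C(F)(F)F)CC1` differs from compound 1 as follows: nitro in place of chloro on an aromatic carbon. Among the measured compounds shown here, no measured step exchanges chloro for nitro; the only step on this ring replaces the whole 3-chlorophenyl with pyridin-3-yl, so it bears only loosely here. Compound 3 is therefore expected to change little, a step of a 1.3-fold lower number from compound 1 to compound 3 (0.12 log units; within the scatter) not beyond the scatter. The estimate for compound 3 is 4000 nM, between 1500 nM and 12000 nM.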

Compound 3, half-maximal cytotoxic concentration: 3890 nM
The estimate for compound 3 lay 1.0-fold (0.01 log units) above the measured number, within the range that was stated.
By their numbers in this assay, from the lowest: compound 2; then compounds 3 and 1 (each within the scatter of the next).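

In this assay, nitro in place of chloro on this aromatic carbon gives a 1.4-fold lower number from compound 1 to compound 3 (0.13 log units; within the scatter) and so leaves the number within the scatter, even though the group that enters is larger by heavy-atom count. The exchange of 3-nitrophenyl for pyridin-3-yl gives a 3.7-fold higher number from compound 2 to compound 3 (0.56 log units; beyond the scatter) and so places compound 3 with compound 1, apart from compound 2. Nothing at hand explains these numbers. From the compounds shown here alone, whether an amine or a carboxylic acid on this carbon would stay with compound 1 and compound 3 or move toward compound 2 remains open.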